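Methoxycarbonyl to carbamoyl: estimating a plasma half-life

The source may report more compounds than this note shows. Statements on the series, on what has been measured and on what is new or still open speak of the compounds shown alone.

Compound 1 `CN(/N=N/c1ccc(C#N)cc1)C(=O)CCCCc1ccc(O)cc1`: 11.8 h
Compound 2 `CC(=O)c1ccc(/N=N/N(C)C(=O)CCCCc2ccc(O)cc2)cc1`: 32.7 h
Compound 3 `COC(=O)c1ccc(/N=N/N(C)C(=O)CCCCc2ccc(O)cc2)cc1`: 17.5 h

All three compounds were measured in an ADME assay on a cell-free system (plasma, Homo sapiens) for metabolic stability, read by HPLC; on this read-out higher numbers stand for a longer-lived compound and lower numbers for a shorter-lived compound. Compound 3 stands within the scatter of both other compounds, as shown by a 1.5-fold higher number from compound 1 to compound 3 (0.17 log units; within the scatter) and by a 1.9-fold lower number from compound 2 to compound 3 (0.27 log units; within the scatter). Only a 2.8-fold higher number from compound 1 to compound 2 (0.44 log units; beyond the scatter) goes beyond the scatter, and that step is modest.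

Compound 4 `CN(/N=N/c1ccc(C(N)=O)cc1)C(=O)CCCCc1ccc(O)cc1` keeps the rest of compound 3 and differs at one place: amino in place of methoxy on a carbonyl carbon. This is amino in place of methoxy on a carbonyl carbon, or methoxycarbonyl to carbamoyl when cut one bond further out.

Within the data shown here, no measured step makes this exact change. The closest evidence is the change at the same carbonyl carbon, a 1.9-fold lower number from compound 2 to compound 3 (0.27 log units; within the scatter), where methoxy replaced methyl and the shift stayed within the scatter. Changes of the whole group on the aromatic carbon have so far stayed modest at most, with compound 1 at 11.8 h and compound 2 at 32.7 h as the two outer values.

The expected step, a 1.3-fold higher number from compound 3 to compound 4 (0.10 log units; within the scatter), therefore lies within the scatter, and its direction is not firmly settled by these data. For compound 4 the estimated half-life is 22 h, with an expected range of 10 h to 48 h.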

Compound 4, half-life in the plasma assay: 55.4 h
Compound 4: middle estimate off by 2.5-fold (0.40 log units), on the low side; measured number above the stated range.
By their numbers in the plasma assay, from the lowest: compounds 1, 3, 2 and 4 (each within the scatter of the next, the first and the last beyond it).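

In the plasma assay, compound 3 gives 17.5 h and compound 4 gives 55.4 h. In the plasma assay, the change at this carbonyl carbon now shows a step beyond the scatter: amino in place of methoxy gives a 3.2-fold higher number from compound 3 to compound 4 (0.50 log units; beyond the scatter), while the earlier step at the same carbon, a 1.9-fold lower number from compound 2 to compound 3 (0.27 log units; within the scatter), stayed within it. Among these compounds, in the plasma assay, carbamoyl also gives the largest step so far among groups on the aromatic carbon, a 4.7-fold higher number from compound 1 to compound 4 (0.67 log units; beyond the scatter), although a 1.7-fold higher number from compound 2 to compound 4 (0.23 log units; within the scatter) stays within the scatter and leaves the acetyl and carbamoyl compounds unseparated. In a physicochemical assay for metabolic stability, read by HPLC, in phosphate buffer, at pH 7.4 (on this read-out higher numbers stand for a longer-lived compound and lower numbers for a shorter-lived compound), compound 3 gives 124 h and compound 4 gives 182 h. Among the compounds shown here, in the physicochemical assay, the same exchange of methoxy for amino gives only a 1.5-fold higher number from compound 3 to compound 4 (0.17 log units; within the scatter) and stays within the scatter, so the separation of this pair seen in plasma has no counterpart in buffer.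

The compounds shown leave open whether a carboxylic acid or a methylamino group on this carbonyl carbon would fall with compound 3 or with compound 4 in the plasma assay. Nothing in the available data accounts for the difference between the two read-outs for this pair.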